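Trifluoromethyl for Fluoro Across Two Cores

A few compounds are considered here, and "the series" means these few. Any claim that something is new, unique, unknown or untested is made for them only; others in the source may bear on it.

Compound 1 `CC(=O)Nc1ccc2oc(-c3ccc(F)cc3)c(O)c(=O)c2c1` gives 34100 nM in an ADME assay on MT4 cells (Homo sapiens) for cytotoxicity, read by MTT assay, with a stated time of 4 days; on this read-out lower numbers stand for higher toxicity in this test and higher numbers for lower toxicity in this test.
Compound 2 `CC(=O)Nc1ccc2oc(-c3ccc(C(F)(F)F)cc3)c(O)c(=O)c2c1` gives 7300 nM in this assay.
Compound 3 `COc1c(-c2ccc(F)cc2)oc2ccc(N)cc2c1=O` gives 141000 nM in this assay.

Compounds 1 and 2 share one core and differ by trifluoromethyl in place of fluoro on an aromatic carbon, a change that brought a 4.7-fold lower number from compound 1 to compound 2 (0.67 log units; beyond the scatter). Compound 3 stands on a different core; how the two cores differ is not broken down here, and compound 3 shows the highest number of the three in this assay. Compound 4 `COc1c(-c2ccc(C(F)(F)F)cc2)oc2ccc(N)cc2c1=O` has not yet been measured; it carries the same change on the core of compound 3, namely (trifluoromethyl in place of fluoro on an aromatic carbon). Within the data shown here, for compound 4 a step of about a 4.7-fold lower number from compound 3 to compound 4 (0.67 log units; beyond the scatter) is expected in this assay, resting on the single earlier instance of this change, which gave a 4.7-fold lower number from compound 1 to compound 2 (0.67 log units; beyond the scatter). Compound 4 is therefore estimated at 30000 nM, most likely between 12000 nM and 75000 nM.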

Compound 4, half-maximal cytotoxic concentration: 290000 nM
Estimate against measurement, compound 4: 9.7-fold (0.99 log units) below; measured number above the stated range.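

On the core of compound 3, trifluoromethyl in place of fluoro gave a 2.1-fold higher number from compound 3 to compound 4 (0.31 log units; beyond the scatter) in this assay, so the direction seen on the core of compound 1 did not carry over. The two instances of this change disagree by more than the scatter of the steps: the same change on two cores in this assay, a 4.7-fold lower number (0.67 log units; beyond the scatter) from compound 1 to compound 2 and a 2.1-fold higher number (0.31 log units; beyond the scatter) from compound 3 to compound 4, 9.6-fold (0.98 log units) apart, beyond the scatter of two such steps This shows that, for these two cores, the outcome of the change in this test depends on the core that carries it, but with only two instances it gives no rule and does not show which feature of the cores is responsible.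

The compounds shown leave open which part of the cores decides the direction of the step. They also leave open how a chloro group or a nitrile in place of fluoro would behave on either core.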